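Removing the para-methyl from a trimethylphenyl amide

A few compounds are considered here, and "the series" means these few. Any claim that something is new, unique, unknown or untested is made for them only; others in the source may bear on it.

Compound 1 `COc1cc2c(Nc3nc4ccc(C(=O)Nc5c(C)cc(C)cc5C)cc4s3)ncnc2cc1OCCCN1CCC(C)CC1`: 6900 nM
Compound 2 `COc1cc2c(Nc3nc4ccc(C(=O)Nc5c(C)cccc5C)cc4s3)ncnc2cc1OCCCN1CCCCC1`: > 100000 nM
Compound 3 `CCN(CC)CCCOc1cc2ncnc(Nc3nc4ccc(C(=O)Nc5c(C)cccc5Cl)cc4s3)c2cc1OC`: 13200 nM

Three compounds share a core and were tested in a functional assay on HCT-116 cells (Homo sapiens) for cytotoxicity, read by WST assay, with a stated time of 72 h; a lower number here means a stronger inhibitor, a higher number a weaker inhibitor. Compound 1 gives 6900 nM, and compound 3 gives 13200 nM, a value within the usual scatter of that of compound 1. Compound 2 reaches only the limit of this assay, > 100000 nM, so no number is known for it (the limit of > 100000 nM in this assay, at which 1 of the 3 values shown sits).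

Compound 4 `COc1cc2c(Nc3nc4ccc(C(=O)Nc5c(C)cccc5C)cc4s3)ncnc2cc1OCCCN1CCC(C)CC1` differs from compound 1 by hydrogen in place of methyl on an aromatic carbon. Within the data shown here, no measured pair shows this change alone. Since compound 2, which also carries the 2,6-dimethylphenyl, gives only the limit > 100000 nM, compound 4 is expected to be weaker than compound 1, with a step of a 3.6-fold higher number from compound 1 to compound 4 (0.56 log units; beyond the scatter). Compound 4 is estimated at 25000 nM, between 7000 nM and 100000 nM.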

Compound 4, half-maximal inhibitory concentration: > 100000 nM
Compound 4: a limit, no number; the forecaster's own chance of this, stated with the estimate: 35%; middle value at least 4.0-fold (0.60 log units) from the limit.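

In this assay compound 4 gives > 100000 nM, which is a limit of the assay and not a number. Among these compounds, with only the 2,4,6-trimethylphenyl changed to 2,6-dimethylphenyl, the change shows for the first time on its own as a large step, an at least 14-fold higher number from compound 1 to compound 4 (1.16 log units; beyond the scatter), so this single methyl on the aromatic ring matters in this pair. The step between compound 2 and compound 4 cannot be read: the limit of > 100000 nM in this assay, at which 2 of the 4 values shown sit.

Going by these compounds, whether an ethyl group, a methoxy group or a fluorine atom at this position would keep the activity of compound 1 remains open. On these data alone, whether the same loss occurs with other amine chains also remains open.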